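Chloro for Bromo on the Aromatic Ring: An Untested Analogue

A few compounds are considered here, and "the series" means these few. Any claim that something is new, unique, unknown or untested is made for them only; others in the source may bear on it.

Of the compounds shown here, two have so far been tested in a functional assay on A549 cells (Homo sapiens) for cytotoxicity, read by MTT assay, with a stated time of 4 days; a higher number here means a weaker inhibitor, a lower number a stronger inhibitor. Compound 1 `COc1ccc(-c2cn(C[C@H]3c4c(ccc(O)c4C)[C@@H]4CC[C@@]5(C)C[C@]43CC5=O)nn2)cc1` gives > 20000 nM, which is a limit of the assay rather than a number. Compound 2 `C=C1C[C@]23C[C@@]1(O)CC[C@@H]2c1cccc(C)c1[C@@H]3Cn1cc(-c2ccc(Br)cc2)nn1` likewise gives > 20000 nM, again a limit. Both values sit at the limit of > 20000 nM in this assay, at which 2 of the 2 values shown sit. Compound 3 `C=C1C[C@]23C[C@@]1(O)CC[C@@H]2c1cccc(C)c1[C@@H]3Cn1cc(-c2ccc(Cl)cc2)nn1` differs from compound 2 by chloro in place of bromo on an aromatic carbon. Among the compounds with values here, with no measured step of this kind to draw on, and compound 2 already resting at the limit, only a small change is expected: a step that the limit leaves unreadable from compound 2 to compound 3. Compound 3 is therefore estimated at 30000 nM, within a range from 10000 nM to 100000 nM, and will most likely be reported as a limit once more.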

Compound 3, half-maximal inhibitory concentration: > 20000 nM
Compound 3: no number, only a limit; the forecaster's own chance of this, stated with the estimate: 85%; the middle value does not contradict the limit.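

Compound 2 and compound 3 both give a limit rather than a number, so the change from bromo to chloro cannot be read as a step: the limit of > 20000 nM in this assay, at which 3 of the 3 values shown sit. From the compounds shown here alone, how strong these compounds truly are, and whether chloro and bromo differ here, stays open.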